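The source may hold more compounds than are shown below. What is called first, only, known or untested is meant among the compounds shown, and "the series" means these compounds.

Compound 1 `N=c1sc2cc(OC(F)(F)F)ccc2n1Cc1ccccc1`: > 10 mg/kg
Compound 2 `N=c1sc2cc(OC(F)(F)F)ccc2n1CC[S+]([O-])c1ccccc1`: 4.2 mg/kg

In a functional assay on the whole organism with Rattus norvegicus as the target (a lower number here means that less compound is needed, a higher number that more compound is needed for the effect), compound 1 gives > 10 mg/kg, which is a limit of the assay and not a number. Among the compounds with values here, compound 2 gives 4.2 mg/kg, the only actual number so far.

Compound 3 `CN(C)CCCn1c(=N)sc2cc(OC(F)(F)F)ccc21` is the next to be tested. It keeps the shared core, but (a group of 4 heavy atoms (3 carbon, 1 nitrogen; no ring) in place of a group of 8 heavy atoms (6 carbon, 1 oxygen, 1 sulfur; one six-membered aromatic ring of carbon only), on a saturated chain carbon, two bonds along the chain from an aromatic nitrogen). Within the data shown here, no measured step shows what such a change does, so the starting point is compound 2 at 4.2 mg/kg. A moderate rise in the dose needed is expected, with an estimated 1.4-fold higher number from compound 2 to compound 3 (0.15 log units; within the scatter). The expected value for compound 3 is 6 mg/kg, within an estimated range of 2 mg/kg to 20 mg/kg.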

Compound 3, dose for half-maximal effect: 9 mg/kg
Compound 3: the middle estimate sits 1.5-fold (0.18 log units) below what was measured; measured number inside the range.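

In this assay, placing (dimethylamino)methyl on a saturated chain carbon, two bonds along the chain from an aromatic nitrogen, in place of a group of 8 heavy atoms (6 carbon, 1 oxygen, 1 sulfur; one six-membered aromatic ring of carbon only) gives a 2.1-fold higher number from compound 2 to compound 3 (0.33 log units; beyond the scatter). Within the data shown here, this is the first readable step at this position, and it shows that the amine keeps a measurable effect but needs a modestly higher dose. The data also give an at least 1.1-fold lower number from compound 1 to compound 3 (0.04 log units; that floor lies within the scatter) with 2-(dimethylamino)ethyl in place of phenyl on a saturated chain carbon bound to an aromatic nitrogen. Compound 1 stands at a limit of the assay, not a number: the limit of > 10 mg/kg in this assay, at which 1 of the 3 values shown sits.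

From the compounds shown here alone, whether a carboxylic acid or a longer chain ending in the amine would change the dose needed at this position remains open.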